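A few compounds are considered here, and "the series" means these few. Any claim that something is new, unique, unknown or untested is made for them only; others in the source may bear on it.

Measured in a functional assay on A549 cells (Homo sapiens) for cytotoxicity, read by fluorescence, with a stated time of 48 h; a lower number here means a stronger inhibitor of growth, a higher number a weaker inhibitor of growth:
- compound 1 `COc1cc(C(=O)/C=C/c2ccc(O)c(O)c2)cc(OC)c1OC`: 2600 nM
- compound 2 `COc1cc(C(=O)/C=C/c2ccc(O)cc2)cc(OC)c1OC`: 8500 nM

Compound 2 holds the higher of the two numbers, so it is the weaker growth inhibitor of the pair. Compound 3 `COc1cc(C(=O)/C=C/c2cccc(O)c2)cc(OC)c1OC` is not yet measured. Its change from compound 2 is 3-hydroxyphenyl in place of 4-hydroxyphenyl on a double-bonded chain carbon bound to a double-bonded chain carbon.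

For the measured compounds named here, one measured step bears on this, and only indirectly, a modest one with hydrogen in place of hydroxy on an aromatic carbon: a 3.3-fold higher number from compound 1 to compound 2 (0.51 log units; beyond the scatter). Going by the values given here, compound 1 carries the hydroxy groups of both compound 2 and compound 3, but no measured pair isolates a moved hydroxy group. In this assay, only a small shift toward a lower number is therefore expected, probably within the scatter. The expected change is a 1.5-fold lower number from compound 2 to compound 3 (0.19 log units; within the scatter). For compound 3 the estimated value is 5500 nM, with an expected range of 1800 nM to 16000 nM.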

Compound 3, concentration for 50% growth inhibition: 1700 nM
For compound 3 the middle estimate is 3.2-fold (0.51 log units) above the measured one; measured number outside the range, below it.
By their numbers in this assay, from the lowest: compounds 3 and 1 (each within the scatter of the next); then compound 2.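

With the atoms unchanged, 3-hydroxyphenyl in place of 4-hydroxyphenyl on the double-bonded chain carbon is enough to shift the number in this assay (a 5.0-fold lower number from compound 2 to compound 3 (0.70 log units; beyond the scatter)), so where the hydroxy group sits matters in this series, not only whether it is present. Compound 3, which has hydrogen in place of a hydroxy group of compound 1, stands within the scatter of it (a 1.5-fold lower number from compound 1 to compound 3 (0.18 log units; within the scatter)), so among these compounds the second hydroxy group of compound 1 is not required for this level of growth inhibition. No measurement is at hand that explains the shift.

Open, on these data alone, is whether an amine or a carboxylic acid in place of the hydroxy group of compound 3 would keep this level. Also open, as far as these compounds go, is whether the shift holds on a different core.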